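The source may hold more compounds than are shown below. What is called first, only, known or untested is meant among the compounds shown, and "the series" means these compounds.

Of the compounds shown here, three sharing one core have been read in a functional assay on MCF7 cells (Homo sapiens) for inhibition, read by MTT assay, with a stated time of 48 h; on this read-out lower numbers stand for stronger inhibition and higher numbers for weaker inhibition. In it, compound 1 (`Brc1ccc2[nH]cc(C(c3ccccc3)c3c[nH]c4ccc(Br)cc34)c2c1`) gives 5500 nM, compound 2 (`COc1ccc(C(c2c[nH]c3ccc(Br)cc23)c2c[nH]c3ccc(Br)cc23)cc1`) gives 2300 nM and compound 3 (`COc1ccc(OC)c(C(c2c[nH]c3ccc(Br)cc23)c2c[nH]c3ccc(Br)cc23)c1`) gives 2800 nM. Compound 3 thus stands within the scatter of both others, as shown by a 1.2-fold higher number from compound 2 to compound 3 (0.09 log units; within the scatter) and by a 2.0-fold lower number from compound 1 to compound 3 (0.29 log units; within the scatter).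

The unmeasured compound 4 (`Brc1ccc2[nH]cc(C(c3ccc4ccccc4c3)c3c[nH]c4ccc(Br)cc34)c2c1`) has naphthalen-2-yl in place of 2,5-dimethoxyphenyl on a saturated chain carbon bound to two aromatic carbons. All three measured steps altered the group at this same place. Only one, a 2.4-fold lower number from compound 1 to compound 2 (0.38 log units; beyond the scatter), lies beyond the scatter, and it is modest. Among the measured compounds shown here, no measured compound carries naphthalen-2-yl, so the data do not show directly what it does here. Compound 4 does share the lack of methoxy with compound 1, at 5500 nM, which gives a slight lean toward a higher number. The expected change in this assay is therefore small and not beyond the scatter, with an estimated 1.3-fold higher number from compound 3 to compound 4 (0.10 log units; within the scatter). For compound 4, the estimated value is 3500 nM, with an expected range from 1400 nM to 8000 nM.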

Compound 4, half-maximal inhibitory concentration: 7100 nM
Beside the measured number, compound 4's estimate is 2.0-fold (0.31 log units) below it, and the stated range covers the measured number.
By their numbers in this assay, from the lowest: compounds 2, 3, 1 and 4 (each within the scatter of the next, the first and the last beyond it).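

In this assay, among the compounds shown here, naphthalen-2-yl on a saturated chain carbon bound to two aromatic carbons gives a 2.5-fold higher number from compound 3 to compound 4 (0.40 log units; beyond the scatter) and a 3.1-fold higher number from compound 2 to compound 4 (0.49 log units; beyond the scatter) and both steps are beyond the scatter though modest, whereas the one earlier step beyond the scatter at this place ran toward a lower number. Set against the plain phenyl group, it gives a 1.3-fold higher number from compound 1 to compound 4 (0.11 log units; within the scatter) and so the group with 2 six-membered aromatic rings cannot be told apart from the group with one. Both methoxy-bearing compounds thus stand clearly lower than compound 4, but this does not make a clean split by methoxy, since compound 3 goes against it with a 2.0-fold lower number from compound 1 to compound 3 (0.29 log units; within the scatter) and stays within the scatter of the unsubstituted phenyl compound.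

No measurement shown accounts for these differences. Still open, on these data alone, is whether a hydroxyl, a dimethylamino group or a carboxylic acid on the phenyl ring would take the number lower than methoxy does, and whether methoxy on the naphthalen-2-yl group would bring compound 4 back toward compound 2.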